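Compound 3 to compound 4: removing the fluoro

The source may report more compounds than this note shows. Statements on the series, on what has been measured and on what is new or still open speak of the compounds shown alone.

In a functional assay on MCF7 cells (Homo sapiens) for inhibition, read by sulforhodamine B assay, with a stated time of 48 h (on this read-out higher numbers stand for weaker inhibition and lower numbers for stronger inhibition), compound 1 `COc1ccc(/C(=N/O)c2cccc3ccccc23)c(OC)c1OC` gives > 20000 nM as a limit and not a number. Compound 2 `COc1ccc(C(O)(Cc2ccc(C)cc2)c2cccc3ccccc23)c(OC)c1OC` gives > 20000 nM as a limit too. Compound 3 `COc1ccc(C(O)(Cc2ccc(F)cc2)c2cccc3ccccc23)c(OC)c1OC` gives 7560 nM and is the only one of the three with a number rather than a limit.

Compound 4 `COc1ccc(C(O)(Cc2ccccc2)c2cccc3ccccc23)c(OC)c1OC` is still to be measured. Against compound 3 it has hydrogen in place of fluoro on an aromatic carbon, para to a large group, so the 4-fluorobenzyl becomes benzyl.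

Among the compounds with values here, one measured step bears on this change: an at least 2.6-fold lower number from compound 2 to compound 3 (0.42 log units; beyond the scatter) with fluoro in place of methyl at the same place. Its starting point is the limit of > 20000 nM in this assay, at which 2 of the 3 values shown sit, and its size is therefore only a bound. Within the data shown here, no measured compound carries hydrogen at this place, so the comparison is one-sided and the expectation is loose. Compound 4 may also read as a limit.

In this assay the expected change is a 1.9-fold higher number from compound 3 to compound 4 (0.27 log units; within the scatter) and this estimate points towards a higher number, meaning weaker inhibition. The estimate for compound 4 is 14000 nM with an expected range from 6000 nM to 32000 nM on this read-out.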

Compound 4, half-maximal inhibitory concentration: 10600 nM
The estimate for compound 4 lay 1.3-fold (0.12 log units) above the measured number; the range from low to high includes it.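

In this assay, the step of a 1.4-fold higher number from compound 3 to compound 4 (0.15 log units; within the scatter) shows that fluoro and hydrogen on this aromatic carbon, para to a large group, cannot be told apart, so 4-fluorobenzyl and benzyl read alike in this series. Within the data shown here, this adds a hydrogen reference point that the earlier compounds lacked: among the three benzyl-type compounds, fluoro and hydrogen both give numbers, while methyl alone gives a limit. From the compounds shown here alone, the methyl to hydrogen comparison gives an at least 1.8-fold lower number from compound 2 to compound 4 (0.27 log units; that floor lies within the scatter), and its true size stays unknown because its starting value is a limit and not a number: the limit of > 20000 nM in this assay, at which 2 of the 4 values shown sit.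

Going by these compounds, whether chloro, bromo, methoxy, trifluoromethyl or an amine at this place would read apart from hydrogen and fluoro remains open, as does whether a carboxylic acid would be tolerated there. With a single cell line shown, it is also open whether fluoro and hydrogen would read alike in other cells, and whether methyl differs from them by a large margin or only a small one.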